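Aryl group variation at the hydrazone nitrogen of the series

This account rests on a few compounds, and the source may have more. Where it says the series, first, only, none or still open, it means among the compounds named here.

In a functional assay on the whole organism for inhibition, with Rattus norvegicus as the target (on this read-out higher numbers stand for an effect only at larger amounts of compound and lower numbers for an effect already at smaller amounts), compound 1 `CC1CCC(=NNc2ccccc2)c2ncc(C(=O)O)c(=O)n21` gives 1.2 umol/kg. Compound 2 `O=C(O)c1cnc2n(c1=O)CCC/C2=N\Nc1ccccc1` stands at a limit of this assay, > 100 umol/kg. Compound 3 `CC1CC/C(=N\Nc2ccc(F)cc2)c2ncc(C(=O)O)c(=O)n21` stands at a limit of this assay too, > 1000 umol/kg, the higher of the two limits shown (the limit of > 1000 umol/kg in this assay, at which 1 of the 3 values shown sits), so no number is known for it. Compound 4 `CC1CC/C(=N\Nc2cccc(Br)c2)c2ncc(C(=O)O)c(=O)n21` is not yet measured in this assay; it differs from compound 3 by 3-bromophenyl in place of 4-fluorophenyl on an amine nitrogen. Within the data shown here, no step between two measured compounds that differ in one place is at hand, so the size of this change is uncertain; the expected step of an at least 10-fold lower number from compound 3 to compound 4 (1.00 log units; beyond the scatter) is taken as a gain beyond the scatter, since compound 1 with its unsubstituted ring gives 1.2 umol/kg. Compound 4 is therefore estimated at 100 umol/kg, with a range from 3 umol/kg to 1000 umol/kg, and a real chance that only a limit is again recorded.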

Compound 4, dose for 50% inhibition: > 320 umol/kg
Compound 4: a limit, no number; the forecaster's own chance of this, stated with the estimate: 50%; at least 3.2-fold (0.50 log units) between middle value and limit.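

Among these compounds, compound 3 and compound 4 both stand at limits in this assay, so no step between them can be read. The compounds shown leave open the size and direction of the change from 4-fluorophenyl to 3-bromophenyl.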